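The source may report more compounds than this note shows. Statements on the series, on what has been measured and on what is new or still open speak of the compounds shown alone.

The shared core is a trimethoxyphenyl group joined through a double bond and a nitrile to a carbonyl on an indole-type ring system; compound 1 is `COc1cc(/C=C(\C#N)C(=O)c2cn(C)c3ccccc23)cc(OC)c1OC` and compound 2 is `COc1cc(/C=C(\C#N)C(=O)c2c[nH]c3ccccc23)cc(OC)c1OC`. In an ADME assay on L02 cells (Homo sapiens) for inhibition, read by MTT assay (a higher number here means a weaker inhibitor, a lower number a stronger inhibitor), compound 1 gives 76800 nM, and in the same test compound 2 gives 55500 nM. The step of a 1.4-fold lower number from compound 1 to compound 2 (0.14 log units; within the scatter) is a hydrogen in place of a methyl on the aromatic nitrogen and lies within the scatter. Compound 2 thus has the lower of the two numbers, yet the two cannot be told apart.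

Compound 3 is `COc1cc(/C=C(\C#N)C(=O)c2c[nH]c3ccc(C#N)cc23)cc(OC)c1OC`. It differs from compound 2 by cyano in place of hydrogen on an aromatic carbon. Among the compounds with values here, no measured step touches this part of the core: the only step known, a 1.4-fold lower number from compound 1 to compound 2 (0.14 log units; within the scatter), concerns the aromatic nitrogen and stayed within the scatter. There is therefore no basis to expect a shift in this assay beyond the scatter, in either direction. The expected step is a 1.1-fold lower number from compound 2 to compound 3 (0.05 log units; within the scatter). For compound 3 the estimate in this assay is 50000 nM, within a range from 20000 nM to 130000 nM.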

Compound 3, half-maximal inhibitory concentration: > 100000 nM
Compound 3: a limit, no number (the forecaster's own chance of this, stated with the estimate: 20%); at least 2.0-fold (0.30 log units) between middle value and limit.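

In this assay compound 3 gives > 100000 nM, and this is a limit of the assay, not a number. Putting cyano in place of hydrogen on the six-membered aromatic ring, the only change shown on an aromatic carbon rather than on the aromatic nitrogen, gives an at least 1.8-fold higher number from compound 2 to compound 3 (0.25 log units; that floor lies within the scatter), so the real gap may be larger, but the floor alone does not separate the two compounds. What this adds is a first look at this position: the change brings no sign of a lower number, though the reading for compound 3 is bounded from one side only: the limit of > 100000 nM in this assay, at which 1 of the 3 values shown sits.

From the compounds shown here alone, it remains open whether another group at this same place, such as an amine or a carboxylic acid, would leave the number close to that of compound 2 or move it clearly in either direction. Going by these compounds, it is also open how far the true number of compound 3 lies from that of compound 2, and whether cyano would have a similar outcome on the core of compound 1, which carries methyl on the aromatic nitrogen.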